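Aromatic Nitrogen Exchanges Carboxymethyl for 4-Methoxyphenyl

The source may hold more compounds than are shown below. What is called first, only, known or untested is meant among the compounds shown, and "the series" means these compounds.

Among the measured compounds shown here, compound 1 `O=C(O)Cn1nc(C(=O)O)cc1-c1ccc(-c2ccc(Cl)cc2Cl)cc1` stands at the high end of the two numbers so far recorded in an assay on isolated protein for inhibition of methionine--tRNA ligase, cytoplasmic (Homo sapiens) (on this read-out lower numbers stand for stronger inhibition and higher numbers for weaker inhibition), where compound 1 gives 100000 nM. For the measured compounds named here, the only other measured compound, compound 2 `O=C(NCc1nn[nH]n1)c1cc(-c2ccc(-c3ccc(Cl)cc3Cl)cc2)n(-c2cccnc2)n1`, gives in this assay 13800 nM, and the gap between these two values lies beyond the usual scatter. Going by the values given here, no pair of measured compounds differing in a single place is available, so no measured step can guide the next change directly.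

Compound 3 `COc1ccc(-n2nc(C(=O)O)cc2-c2ccc(-c3ccc(Cl)cc3Cl)cc2)cc1` differs from compound 1 in one way: 4-methoxyphenyl in place of carboxymethyl on an aromatic nitrogen. The change removes a hydrogen-bond donor and adds a six-membered aromatic ring. On the two numbers available, compound 3 is expected to show a step of a 4.0-fold lower number from compound 1 to compound 3 (0.60 log units; beyond the scatter), a moderate move toward stronger inhibition. Compound 3 is estimated at 25000 nM, within a range from 6000 nM to 100000 nM.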

Compound 3, half-maximal inhibitory concentration: > 100000 nM
Compound 3 gave a limit, no number (the forecaster's own chance of this, stated with the estimate: 25%); middle value at least 4.0-fold (0.60 log units) away from the limit.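

Exchanging carboxymethyl for 4-methoxyphenyl on this aromatic nitrogen brought no gain in this assay: the change gives a number no lower from compound 1 to compound 3 (the limit leaves the size open). With the carboxy group kept on the ring, losing the hydrogen-bond donor of carboxymethyl and adding a six-membered aromatic ring of carbon only therefore gave no measurable strengthening of inhibition at this position. Compound 3 gives only a limit and not a number, and the size of the step cannot be read: the limit of > 100000 nM in this assay, at which 1 of the 3 values shown sits.

The compounds shown leave open how this assay responds on this nitrogen to a plain methyl group or an aminoethyl chain, neither of which is among them. They also leave open whether 4-methoxyphenyl behaves differently when an amide takes the place of the carboxy group on the shared core.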